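The source may hold more compounds than are shown below. What is called first, only, known or untested is meant among the compounds shown, and "the series" means these compounds.

Compound 1 `CCCOC(=O)C1=C(C)N(C)C(=O)NC1c1ccsc1` and compound 2 `CC1=C(C(=O)OCC(C)C)C(c2ccsc2)NC(=O)N1C` share one core and differ only in the chain on the oxygen next to a carbonyl group. In an assay on membranes from HeLa cells for displacement of a labelled ligand from adenosine receptor A3 (Homo sapiens), read by scintillation counting, with a stated time of 180 min, tested at 1 uM (a higher number here means more inhibition at the concentration tested (going by the name of the read-out), a lower number less inhibition), compound 1 gives 11%, and in this assay compound 2 gives 4%. Compound 2 stands lowest of the two numbers, with compound 1 the nearest at a gap within the scatter, so the two are read as alike. Compound 3 `CC1=C(C(=O)OC(C)(C)C)C(c2ccsc2)NC(=O)N1C` is not yet measured; it differs from compound 2 by tert-butyl in place of isobutyl on an oxygen next to a carbonyl group. Within the data shown here, the one measured step that bears on this change, since it also alters the chain on that oxygen, is a number 7 percentage points lower from compound 1 to compound 2 (within the scatter). Both numbers are low and that step did not leave the scatter, so for the change to compound 3 no step beyond the scatter is expected in this assay. The estimated step is a number 1 percentage points higher from compound 2 to compound 3 (within the scatter). The expected value of compound 3 in this assay is 5%, in the range -5% to 15%.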

Compound 3, a percentage reported as inhibition, at one concentration (the size of the read-out at that concentration, not a potency): 14%
Compound 3: the middle estimate sits 9 percentage points below what was measured, and the stated range covers the measured number.
By their numbers in this assay, from the lowest: compounds 2, 1 and 3 (each within the scatter of the next).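

In this assay, tert-butyl in place of isobutyl on an oxygen next to a carbonyl group gives a number 10 percentage points higher from compound 2 to compound 3 (within the scatter) and tert-butyl in place of propyl at the same place gives a number 3 percentage points higher from compound 1 to compound 3 (within the scatter), so neither change moves the number beyond the usual scatter. The position now carries three chains, propyl, isobutyl and tert-butyl, and all three read as alike in this assay, including the pair with the same atoms joined differently, which adds a second change of chain shape at this oxygen to the single one seen before. Nothing at hand explains how these chains read, and none of the available data speaks to the reason for this flat picture.

All three chains are of similar size and carry no ring, so the compounds shown leave open whether anything placed on this oxygen can lift the inhibition clear of the scatter at the tested concentration. Going by these compounds, a longer chain such as hexyl, a benzyl group, or a carboxylic acid in place of the ester would test that, and the other parts of the shared core remain open as well.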